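A few compounds are considered here, and "the series" means these few. Any claim that something is new, unique, unknown or untested is made for them only; others in the source may bear on it.

Of the compounds shown here, three sharing one core have been tested in an ADME assay on CCRF-CEM cells (Homo sapiens) for cytotoxicity, read by MTT assay, with a stated time of 5 days; on this read-out lower numbers stand for higher toxicity in this test and higher numbers for lower toxicity in this test. Compound 1, `COc1cc(Cc2cnc(/N=C3\C(=O)N(CN4CCN(Cc5ccccc5)CC4)c4ccc(Cl)cc43)nc2N)cc(OC)c1OC`, gives 94.7 ug/mL. Compound 2, `COc1cc(Cc2cnc(/N=C3\C(=O)N(CN4CCC(C)CC4)c4ccc(Cl)cc43)nc2N)cc(OC)c1OC`, gives 46.3 ug/mL. Compound 3, `COc1cc(Cc2cnc(/N=C3\C(=O)N(CN4CCN(c5c(F)cc6c(=O)c(C(=O)O)cn(C7CC7)c6c5F)CC4C)c4ccc(Cl)cc43)nc2N)cc(OC)c1OC`, gives 67 ug/mL. Compound 2 stands at the lowest of the three numbers, but its distance to compound 3 is within the usual scatter of this test, so the two cannot be told apart; only compound 1 stands apart from compound 2, with a number that is higher by a margin beyond the scatter.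

The next compound, compound 4, is `CCN(CC)CN1C(=O)/C(=N\c2ncc(Cc3cc(OC)c(OC)c(OC)c3)c(N)n2)c2cc(Cl)ccc21`. It is compound 2 with one change: diethylamino in place of 4-methylpiperidin-1-yl on a saturated chain carbon bound to an amide-type nitrogen in a ring. For the measured compounds named here, no pair of measured compounds shows a step of this kind, so there is nothing measured to lean on. The three numbers in hand all lie in a narrow band, and the change is a modest one at a position where compound 1 and compound 2 already differ without a dramatic effect, so the expected step from compound 2 to compound 4 is a 1.2-fold higher number from compound 2 to compound 4 (0.07 log units; within the scatter), which is no step beyond the scatter. Compound 4 is therefore estimated at 55 ug/mL, with a range from 25 ug/mL to 120 ug/mL.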

Compound 4, half-maximal cytotoxic concentration: 98.4 ug/mL
For compound 4 the middle estimate is 1.8-fold (0.25 log units) below the measured one; low and high end bracket the measured number.
By their numbers in this assay, from the lowest: compounds 2, 3, 1 and 4 (each within the scatter of the next, the first and the last beyond it).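

In this assay, for the compounds shown here, replacing the ring-bearing 4-methylpiperidin-1-yl with the open-chain diethylamino gives a 2.1-fold higher number from compound 2 to compound 4 (0.33 log units; beyond the scatter) and is the first single change measured at this position. It shows that the amine on the saturated chain carbon bound to an amide-type nitrogen in a ring can shift the number beyond the usual scatter, here towards lower toxicity in this test, even though the rest of the molecule stays the same and both groups count one nitrogen, no hydrogen-bond donor and one hydrogen-bond acceptor. Nothing available explains why this change moves the number.

The step combines several differences, since the amine loses its ring, its methyl group and two heavy atoms at once, so this single pair cannot show which of them matters. Piperidin-1-yl would isolate the methyl group within the ring, while dimethylamino and morpholin-4-yl would show how this read-out responds to a shorter open-chain amine and to a ring holding an oxygen atom.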